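The source may report more compounds than this note shows. Statements on the series, on what has been measured and on what is new or still open speak of the compounds shown alone.

Measured in an ADME assay on microsomes from liver (Mus musculus) for metabolic stability; a higher number here means that the compound lasts longer, a lower number that the compound disappears faster:
- compound 1 `CCC(CC)(c1nnc[nH]1)c1ccc(-c2ccc3cc(F)cc(F)c3c2)[nH]c1=O`: 1.09 h
- compound 2 `CC(C)C(Cc1ncc[nH]1)c1ccc(-c2ccc3cccc(F)c3c2)[nH]c1=O`: < 0.0667 h
- compound 3 `CCn1ncc2c(F)cc(-c3ccc(C(CC)(CC)c4nncn4C)c(=O)[nH]3)cc21`: > 3 h

Of these three, only compound 1 has a true number. Compound 2 gives < 0.0667 h, which is a limit of the assay and not a number, and it marks the short-lived end of this small set. Compound 3 gives > 3 h, which is also a limit.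

Compound 4 `CC(C)C(c1ccc(-c2ccc3cccc(F)c3c2)[nH]c1=O)N1CCN/C1=N\C#N` is compound 2 with one change: a group of 8 heavy atoms (4 carbon, 4 nitrogen; one five-membered non-aromatic ring with 2 hetero atoms) in place of a group of 6 heavy atoms (4 carbon, 2 nitrogen; one five-membered aromatic ring with 2 hetero atoms), on a saturated chain carbon bound to an aromatic carbon and a saturated chain carbon. The (1H-imidazol-2-yl)methyl group leaves, and a group with a five-membered non-aromatic ring enters on the same saturated chain carbon.

Among the measured compounds shown here, no two measured compounds differ in one place only, so no measured step shows the size of this change in this assay. A modest rise is expected, because compound 2 stands at the limit of < 0.0667 h in this assay, at which 1 of the 3 values shown sits. The expected size is an at least 2.9-fold higher number from compound 2 to compound 4 (0.47 log units; beyond the scatter). For compound 4 the estimate is 0.2 h, with an expected range from 0.06 h to 0.8 h.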

Compound 4, half-life: 0.207 h
Compound 4: middle estimate off by 1.0-fold (0.01 log units), on the low side, and the stated range covers the measured number.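

Among the compounds shown here, this is the first measured step at this position: on a saturated chain carbon bound to an aromatic carbon and a saturated chain carbon, a group with a five-membered non-aromatic ring in place of (1H-imidazol-2-yl)methyl gives an at least 3.1-fold higher number from compound 2 to compound 4 (0.49 log units; beyond the scatter) in this assay. Compound 2 gives < 0.0667 h, which is a limit of the assay. Compound 4 has a true number at this position, yet the full size of the step stays unknown because it starts from a limit: the limit of < 0.0667 h in this assay, at which 1 of the 4 values shown sits.

This single step leaves open whether the rise goes with the non-aromatic ring or with the nitrile it carries. From the compounds shown here alone, how the same ring would behave with a carbonyl in place of the nitrile-bearing double bond, or how a plain amine would behave on that chain carbon, also stays open.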